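A few compounds are considered here, and "the series" means these few. Any claim that something is new, unique, unknown or untested is made for them only; others in the source may bear on it.

Measured compounds:
- Compound 1 `CN1CCc2cccc(c2)Oc2ccc(cc2)CCC1=O`: in a functional assay on L1210 cells (Mus musculus) for cytotoxicity (a lower number here means a stronger inhibitor, a higher number a weaker inhibitor), compound 1 gives > 100 ug/mL, which is a limit of the assay.
- Compound 2 `O=C1CCc2ccc(cc2)Oc2cccc(c2)CCN1`: in this assay compound 2 gives > 100 ug/mL, also a limit.
- Compound 3 `COC(=O)[C@@H]1Cc2ccc(OC)c(c2)Oc2ccc(cc2)C[C@H](N(C)C(=O)OC(C)(C)C)C(=O)N1C`: in this assay compound 3 gives 0.03 ug/mL.

The change hydrogen in place of methyl on an amide-type nitrogen in a ring gives a step that the two limits leave unreadable from compound 1 to compound 2; it stays unreadable because of the limit of > 100 ug/mL in this assay, at which 2 of the 3 values shown sit.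

Compound 4 `COC(=O)[C@@H]1Cc2ccc(OC)c(c2)Oc2ccc(cc2)C[C@H](N(C)C(=O)OC(C)(C)C)C(=O)N1` carries the same kind of change, (hydrogen in place of methyl on an amide-type nitrogen in a ring), applied to compound 3. The surroundings differ: here the nitrogen sits next to the ring atom that bears a methoxycarbonyl group and two ring bonds from the ring atom that bears a methyl(tert-butoxycarbonyl)amino group, while in compound 1 no such groups are noted. The difference between the cores of compound 1 and compound 3 is not broken down here.

No readable step guides this change, so the expected step of a 3.3-fold higher number from compound 3 to compound 4 (0.52 log units; beyond the scatter) is set small and uncertain, resting on compound 3 giving 0.03 ug/mL. Compound 4 is estimated at 0.1 ug/mL, from 0.02 ug/mL to 1 ug/mL.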

Compound 4, half-maximal inhibitory concentration: 0.06 ug/mL
For compound 4 the middle estimate is 1.7-fold (0.22 log units) above the measured one; the range from low to high includes it.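

In this assay, hydrogen in place of methyl on an amide-type nitrogen in a ring gives a 2.0-fold higher number from compound 3 to compound 4 (0.30 log units; within the scatter), so on the core of compound 3 the change leaves the value within the scatter. This is a single readable step, and it does not show that the change behaves alike on another core. The same change on the core of compound 1 cannot be read, because compound 1 and compound 2 both stand at a limit: the limit of > 100 ug/mL in this assay, at which 2 of the 4 values shown sit.

The compounds shown leave open how an ethyl group on that ring nitrogen would read in this assay. Also open, going by these compounds, is how a carboxylic acid in place of the methoxycarbonyl group, or a free amine in place of the methyl(tert-butoxycarbonyl)amino group, would read there.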